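The source may report more compounds than this note shows. Statements on the series, on what has been measured and on what is new or still open speak of the compounds shown alone.

Of the compounds shown here, three built on one shared core have been tested in a functional assay on HCC827 cells (Homo sapiens) for antiproliferative activity, read by sulforhodamine B assay, with a stated time of 72 h; a lower number here means a stronger inhibitor, a higher number a weaker inhibitor. Compound 1 `CN(CCNCc1cn(-c2ccc(F)cc2)nn1)CCNc1ccnc2cc(Cl)ccc12` gives 19000 nM, compound 2 `CN(CCNCc1cn(-c2ccc(Br)cc2)nn1)CCNc1ccnc2cc(Cl)ccc12` gives 11000 nM, and compound 3 `CN(CCNCc1cn(Cc2nc3cc(Cl)ccc3[nH]2)nn1)CCNc1ccnc2cc(Cl)ccc12` gives 65000 nM. On these numbers compound 2 has the lowest value, with compound 1 nearest, a 1.7-fold lower number from compound 1 to compound 2 (0.24 log units; within the scatter), a gap that does not separate the two, and compound 3 furthest, a 5.9-fold higher number from compound 2 to compound 3 (0.77 log units; beyond the scatter).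

Compound 4 `CN(CCNCc1cn(-c2ccnc3cc(Cl)ccc23)nn1)CCNc1ccnc2cc(Cl)ccc12` has not yet been measured. It differs from compound 2 in one place: 7-chloroquinolin-4-yl in place of 4-bromophenyl on an aromatic nitrogen. Going by the values given here, two measured steps bear on this change, though neither covers it directly. Putting bromo in place of fluoro on an aromatic carbon, a 1.7-fold lower number from compound 1 to compound 2 (0.24 log units; within the scatter), stayed within the scatter of this assay, while putting (5-chloro-1H-benzimidazol-2-yl)methyl in place of 4-bromophenyl on the aromatic nitrogen, a 5.9-fold higher number from compound 2 to compound 3 (0.77 log units; beyond the scatter), raised the number modestly. The present change is larger than the first and of a different kind from the second, so no direction is established. For compound 4 a step within the scatter or a modest shift either way is expected, a 1.2-fold lower number from compound 2 to compound 4 (0.09 log units; within the scatter). Compound 4 is thus estimated to give about 9000 nM in this assay, with a range from 2500 nM to 30000 nM.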

Compound 4, half-maximal inhibitory concentration: 18000 nM
Estimate against measurement, compound 4: 2.0-fold (0.30 log units) below, within the range that was stated.
By their numbers in this assay, from the lowest: compounds 2, 4 and 1 (each within the scatter of the next); then compound 3.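

In this assay, the aromatic nitrogen of the five-membered ring with 3 nitrogen carries the larger 7-chloroquinolin-4-yl, with 11 heavy atoms and a hydrogen-bond acceptor, without any step beyond the scatter: a 1.6-fold higher number from compound 2 to compound 4 (0.21 log units; within the scatter) and a 1.1-fold lower number from compound 1 to compound 4 (0.02 log units; within the scatter). The new group also separates from the other large substituent at this position, with a 3.6-fold lower number from compound 3 to compound 4 (0.56 log units; beyond the scatter), so a second aromatic ring on this nitrogen does not by itself produce the higher number seen with (5-chloro-1H-benzimidazol-2-yl)methyl. No measurement is available to explain why these groups behave as they do.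

Compound 3 differs from the other compounds in both its ring system and its methylene link to the nitrogen, so the compounds shown cannot say which of these goes with its higher number, and a plain benzyl group on the same nitrogen would be needed to separate them. Also open, going by these compounds, is whether an amine or a carboxylic acid on the aromatic ring would take the number outside the narrow spread of compounds 1, 2 and 4.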